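The source may report more compounds than this note shows. Statements on the series, on what has been measured and on what is new or still open speak of the compounds shown alone.

Measured so far:
Compound 1, `COCC#Cc1cc(C(O)(C(F)(F)F)C(F)(F)F)cnc1N1CCN(S(=O)(=O)c2ccc(N)nc2)CC1`, gives 399 mL.min-1.g-1.
Compound 2, `Nc1ccc(S(=O)(=O)N2CCN(c3ncc(C(O)(C(F)(F)F)C(F)(F)F)cc3C#CCCO)CC2)cn1`, gives 68 mL.min-1.g-1.
Compound 3, `NC(=O)c1cccc(-c2cc(C(O)(C(F)(F)F)C(F)(F)F)cnc2N2CCN(S(=O)(=O)c3ccc(N)nc3)CC2)c1`, gives 63 mL.min-1.g-1.

These three share one core and differ only in the group on one aromatic carbon of the pyridine, read in an ADME assay (liver) for metabolic stability, with Liver microsome (Rattus norvegicus) as the target, using microsomes and NADPH, with a stated time of 30 min, tested at 1 uM; a higher number here means faster removal of the compound, a lower number slower removal. Compound 2 sits at the second highest of the three numbers, but its step to compound 3, a 1.1-fold lower number from compound 2 to compound 3 (0.03 log units; within the scatter), is within the scatter, so the two cannot be told apart; compound 1 stands clearly apart, as a 5.9-fold lower number from compound 1 to compound 2 (0.77 log units; beyond the scatter) and a 6.3-fold lower number from compound 1 to compound 3 (0.80 log units; beyond the scatter) show.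

The next compound, compound 4, `Nc1ccc(S(=O)(=O)N2CCN(c3ncc(C(O)(C(F)(F)F)C(F)(F)F)cc3-c3cncc(F)c3)CC2)cn1`, differs from compound 2 in one place: 5-fluoropyridin-3-yl in place of 4-hydroxybut-1-yn-1-yl on an aromatic carbon. Among the compounds with values here, the most relevant measured step is the one from compound 2 to compound 3, where an aromatic ring likewise replaced the 4-hydroxybut-1-yn-1-yl group and the number barely moved. On that basis the step of a 1.0-fold higher number from compound 2 to compound 4 (0.01 log units; within the scatter) is expected to stay within the scatter, with no clear direction. Compound 4 is therefore estimated at 70 mL.min-1.g-1, within a range of 35 mL.min-1.g-1 to 140 mL.min-1.g-1.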

Compound 4, intrinsic clearance in microsomes: 19 mL.min-1.g-1
Beside the measured number, compound 4's estimate is 3.7-fold (0.57 log units) above it; the whole stated range lies above it.
By their numbers in this assay, from the lowest: compound 4; then compounds 3 and 2 (each within the scatter of the next); then compound 1.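

In this assay, the two earlier groups gave no sign that the choice of group at this aromatic carbon could push the number lower than theirs, yet 5-fluoropyridin-3-yl does so against both the chain (a 3.6-fold lower number from compound 2 to compound 4 (0.55 log units; beyond the scatter)) and the other aromatic ring (a 3.3-fold lower number from compound 3 to compound 4 (0.52 log units; beyond the scatter)). An aromatic ring at this position is therefore not enough to fix the number, since the two rings shown clearly differ, and this one position now spans a large range (a 21-fold lower number from compound 1 to compound 4 (1.32 log units; beyond the scatter)). Nothing available explains why this ring gives the lowest number.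

Still open, as far as these compounds go, is whether the fluorine or the ring nitrogen of the new group matters more, which a plain phenyl or an unsubstituted pyridin-3-yl would help separate. From the compounds shown here alone, how an amine or a carboxylic acid at this position would read also remains unknown.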